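This account rests on a few compounds, and the source may have more. Where it says the series, first, only, none or still open, it means among the compounds named here.

Measured in a functional assay on KB cells (Homo sapiens) for inhibition; a lower number here means a stronger inhibitor, a higher number a weaker inhibitor:
- Compound 1 `Clc1cc2nc(Cl)n(Cc3ccccc3)c2cc1Cl`: > 100000 nM
- Compound 2 `Cc1cccc(Cn2c(Cl)nc3cc(Cl)c(Cl)cc32)c1`: > 100000 nM
- Compound 3 `Clc1cc2nc(Cl)n(Cc3ccccc3Cl)c2cc1Cl`: 156000 nM

The starting point gives no exact number. Compound 1 shows > 100000 nM, which is a limit. Compound 2 shows > 100000 nM, which is also a limit. For the measured compounds named here, compound 3 is the only one with a true number, and compound 3 gives 156000 nM, a very weak result.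

The next compound to be measured is compound 4 `Fc1ccc(Cn2c(Cl)nc3cc(Cl)c(Cl)cc32)cc1`. It keeps the core of compound 1 and changes one thing: fluoro in place of hydrogen on an aromatic carbon. In words, this is fluoro in place of hydrogen on an aromatic carbon, para to a large group.

Two other single changes bear on this one. Methyl in place of hydrogen gave a step that the two limits leave unreadable from compound 1 to compound 2, and chloro in place of hydrogen gave a step that the limit leaves unreadable from compound 1 to compound 3. Neither size can be read because of the limit of > 100000 nM in this assay, at which 2 of the 3 values shown sit. These compounds therefore offer no sign of a gain in strength, and they give no measured size to carry over.

With no firm basis for a direction, no clear change is expected, and the expected step is a step that the limit leaves unreadable from compound 1 to compound 4. A limit is also a likely result. For compound 4 the estimated value is 150000 nM. The expected range for compound 4 runs from 80000 nM to 300000 nM.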

Compound 4, half-maximal inhibitory concentration: > 100000 nM
Compound 4 ended at the assay's limit (the forecaster's own chance of this, stated with the estimate: 60%); the middle value does not contradict the limit.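

Compound 1 and compound 4 each end at a limit rather than a true number, so the size of the step between them, fluoro in place of hydrogen, cannot be read: the limit of > 100000 nM in this assay, at which 3 of the 4 values shown sit.

The compounds shown leave open whether fluoro, methyl or chloro in place of hydrogen on an aromatic carbon changes strength at all in this assay.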